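From Pyridin-2-yl to Methoxy on the Shared Core

The source may hold more compounds than are shown below. What is called first, only, known or untested is meant among the compounds shown, and "the series" means these compounds.

In a functional assay on HepG2 cells (Homo sapiens) for inhibition, read by MTT assay, with a stated time of 72 h (a lower number here means a stronger inhibitor, a higher number a weaker inhibitor), compound 3 `CC(C)(C)n1cc2c(n1)C(=O)CC1(CCN(C(=O)c3cc(-c4ccccn4)nc4ccccc34)CC1)O2` gives 1500 nM and compound 2 `CC(C)(C)n1cc2c(n1)C(=O)CC1(CCN(C(=O)c3cc(-c4ccc(Br)cc4)nc4ccccc34)CC1)O2` gives 820 nM, and a 1.8-fold higher number from compound 2 to compound 3 (0.26 log units; within the scatter) leaves the two level. Compound 1 `CC(C)(C)n1cc2c(n1)C(=O)CC1(CCN(C(=O)c3cc(-c4ccccc4Cl)nc4ccccc34)CC1)O2` reports only a limit, > 10000 nM. Compound 4 `COc1cc(C(=O)N2CCC3(CC2)CC(=O)c2nn(C(C)(C)C)cc2O3)c2ccccc2n1` carries methoxy in place of pyridin-2-yl on an aromatic carbon, which is methoxy in place of pyridin-2-yl, next to the ring nitrogen. Two steps at this same place, an at least 12-fold lower number from compound 1 to compound 2 (1.08 log units; beyond the scatter) and an at least 6.6-fold lower number from compound 1 to compound 3 (0.82 log units; beyond the scatter), show that the group there can matter greatly. For the measured compounds named here, each of them exchanges one aromatic ring for another, so no measured step removes the ring altogether. A modest move towards weaker inhibition is expected, an estimated 2.3-fold higher number from compound 3 to compound 4 (0.37 log units; beyond the scatter). Compound 4 is estimated at 3500 nM, with an expected range of 1000 nM to 10000 nM.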

Compound 4, half-maximal inhibitory concentration: > 10000 nM
Compound 4 ended at the assay's limit (the forecaster's own chance of this, stated with the estimate: 20%); middle value at least 2.8-fold (0.45 log units) from the limit.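

In this assay, methoxy, which brings no ring, gives an at least 6.6-fold higher number from compound 3 to compound 4 (0.82 log units; beyond the scatter) and an at least 12-fold higher number from compound 2 to compound 4 (1.08 log units; beyond the scatter) at this place on the shared core. For the compounds shown here, the earlier compounds showed only one aromatic ring exchanged for another, so these are the first steps that take the ring away, and a readable value is lost even though compound 1 shows that keeping a ring does not ensure one. Compound 4 reports only a limit, and it is the same one as for compound 1, so the step between them cannot be read: the limit of > 10000 nM in this assay, at which 2 of the 4 values shown sit.

On these data alone, whether an amine, or a longer chain such as ethoxy, would return a readable value at this place remains open. As far as these compounds go, it is also open whether 3-bromophenyl or 4-chlorophenyl would behave like 4-bromophenyl or like 2-chlorophenyl.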